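Phenyl to phenoxy on the long chain of compound 3

A few compounds are considered here, and "the series" means these few. Any claim that something is new, unique, unknown or untested is made for them only; others in the source may bear on it.

Measured in an assay on membranes from lung for binding affinity to cysteinyl leukotriene receptor 1 (Cavia porcellus); a lower number here means a stronger inhibitor, a higher number a weaker inhibitor:
- compound 1 `O=C(O)CCC[C@H](O)[C@@H](/C=C\CCc1ccccc1)Sc1ccc(C(=O)O)cc1`, a limit only: < 100000 nM; < 100000 nM (2 entries)
- compound 2 `O=C(O)CCC[C@H](O)[C@@H](/C=C/CCCc1ccccc1)Sc1ccc(C(=O)O)cc1`, a limit only: < 100000 nM
- compound 3 `O=C(O)CCC[C@H](O)[C@@H](/C=C\CCCCCCCCc1ccccc1)Sc1ccc(C(=O)O)cc1`: 316 nM

Going by the values given here, compound 3 holds the only number in this assay; the other two entries sit at the assay limit, as the limit of < 100000 nM in this assay, at which 1 of the 3 values shown sits, records. Among the compounds with values here, no step between measured compounds is therefore available, and nothing shows how a change at the far end of the chain moves affinity.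

Compound 4 `O=C(O)CCC[C@H](O)[C@@H](/C=C\CCCCCCCCOc1ccccc1)Sc1ccc(C(=O)O)cc1` differs from compound 3 by phenoxy in place of phenyl on a saturated chain carbon, eight bonds along the chain from a double-bonded chain carbon. Within the data shown here, with no measured step to lean on, the change is expected to stay within the scatter or move weaker by a little. The expected step of a 1.3-fold higher number from compound 3 to compound 4 (0.10 log units; within the scatter) is small. Compound 4 is estimated at 400 nM, between 120 nM and 1500 nM.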

Compound 4, inhibition constant: 631 nM
Compound 4: middle estimate off by 1.6-fold (0.20 log units), on the low side; the measured number falls inside the stated range.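

Going by these compounds alone, the first measured step, in this assay, is a 2.0-fold higher number from compound 3 to compound 4 (0.30 log units; within the scatter). At this place, on a saturated chain carbon, eight bonds along the chain from a double-bonded chain carbon, the assay does not separate phenoxy from phenyl, so a chain oxygen with its hydrogen-bond acceptor is tolerated. No measured property bears on this result.

On these data alone, whether an amine at the same place, or a longer chain carrying the phenoxy, would behave alike remains open. Also open, as far as these compounds go, is how a carboxylic acid on the terminal ring would read.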